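The compounds below may be only part of what the source reports. "The series", "measured", "known", "first", "only" and "open" are said of these compounds alone.

Three compounds built on one shared core were tested in a functional assay on HT-29 cells (Homo sapiens) for cytotoxicity, read by MTT assay, with a stated time of 48 h; on this read-out lower numbers stand for stronger inhibition and higher numbers for weaker inhibition. Compound 1 `COc1cc(-c2nnc(SCc3ccccc3)n2/N=C/c2ccccc2)cc(OC)c1OC` carries a benzylsulfanyl group on that core. In this assay compound 1 reaches only a limit of the assay, > 200000 nM. Compound 2 `COc1cc(-c2nnc(SCc3ccccc3Cl)n2/N=C/c2ccccc2)cc(OC)c1OC` differs from compound 1 by hydrogen in place of chloro on an aromatic carbon. In this assay compound 2 likewise gives only a limit, > 200000 nM. Compound 3 `COc1ccc(/C=N/n2c(SCc3ccccc3Cl)nnc2-c2cc(OC)c(OC)c(OC)c2)c(OC)c1` differs from compound 2 by 2,4-dimethoxyphenyl in place of phenyl on a carbon with a double bond to nitrogen. In this assay compound 3 also stops at a limit, > 200000 nM. Both measured steps, a step that the two limits leave unreadable from compound 2 to compound 1 and a step that the two limits leave unreadable from compound 2 to compound 3, are therefore unreadable because every value sits at the limit of > 200000 nM in this assay, at which 3 of the 3 values shown sit.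

Compound 4 `COc1ccc(/C=N/n2c(SCc3ccccc3)nnc2-c2cc(OC)c(OC)c(OC)c2)c(OC)c1` has not yet been measured; it differs from compound 3 by hydrogen in place of chloro on an aromatic carbon, which is the same change as that from compound 2 to compound 1, at the same place. Compound 4 is expected to show a step of a number no higher from compound 3 to compound 4 (the limit leaves the size open), an expectation resting on (the limit of > 200000 nM in this assay, at which 3 of the 3 values shown sit), where the earlier pair also sat. Compound 4 is thus estimated at 200000 nM, within 100000 nM to 400000 nM, and most likely only another limit will be reported.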

Compound 4, half-maximal inhibitory concentration: > 200000 nM
Compound 4: a limit, no number; the forecaster's own chance of this, stated with the estimate: 85%; the middle value lies on the limit itself.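

In this assay compound 4 gives > 200000 nM, again a limit and not a number. No step from compound 3 or compound 1 to compound 4 can be read, because all the values sit at the same limit: the limit of > 200000 nM in this assay, at which 4 of the 4 values shown sit.

The compounds shown leave open how strongly any of them acts on these cells, and whether swapping chloro for hydrogen or phenyl for 2,4-dimethoxyphenyl changes that.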